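Acid in place of amide on a CDK8 series

The source may hold more compounds than are shown below. What is called first, only, known or untested is meant among the compounds shown, and "the series" means these compounds.

Three compounds with the same core were measured in an assay on a protein complex for inhibition of CDK8/Cyclin C (Homo sapiens), with a stated time of 1 h, tested at 10 uM; on this read-out higher numbers stand for more inhibition at the one concentration tested (going by the name of the read-out) and lower numbers for less inhibition. Compound 1 `NNC(=O)CCc1ccncc1-c1ccc2ccccc2c1` gives 102%, compound 3 `COC1CN(C(=O)/C=C/c2ccncc2-c2ccc3ccccc3c2)C1` gives 100%, and compound 2 `CNC(=O)/C=C/c1ccncc1-c1ccc2cc[nH]c2c1` gives 103%. The number for compound 2 sits within the scatter of both compound 1 and compound 3, so the three cannot be told apart on this read-out. Compound 4 `O=C(O)/C=C/c1ccncc1-c1ccc2cc[nH]c2c1` has not yet been measured; it differs from compound 2 by hydroxy in place of methylamino on a carbonyl carbon. Since every measured number is already high, little room remains upward; a modest drop, possibly still within the scatter, is expected. The expected step from compound 2 is a number 13 percentage points lower from compound 2 to compound 4 (beyond the scatter). Compound 4 is thus estimated at 90%, in the range from 65% to 105%.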

Compound 4, a percentage reported as inhibition, at one concentration (the size of the read-out at that concentration, not a potency): 103%
The estimate for compound 4 lay 13 percentage points below the measured number, within the range that was stated.
By their numbers in this assay, from the lowest: compounds 3, 1, 2 and 4 (each within the scatter of the next).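

In this assay the carbonyl carbon takes hydroxy in place of methylamino with no change at the digits printed from compound 2 to compound 4 (within the scatter) and nothing more to report on this read-out. So, at the one concentration tested, a carboxy group serves here as well as a methylcarbamoyl group, a comparison the earlier compounds did not offer. Nothing available explains this result.

A single concentration gives no potency, so compound 2 and compound 4 could still differ at lower concentrations. Going by these compounds, how an ester or a longer chain ending in an amine would fare on this carbonyl carbon stays open.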